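Swapping the Aryl Thioether for Phenethyl

The source may report more compounds than this note shows. Statements on the series, on what has been measured and on what is new or still open speak of the compounds shown alone.

Values in a functional assay on A549 cells (Homo sapiens) for inhibition, read by CCK-8 assay, with a stated time of 72 h, tested at 2 uM; on this read-out higher numbers stand for more inhibition of growth at the one concentration tested and lower numbers for less inhibition of growth
- compound 1 `COc1ccc(SCc2ccc(C(=O)Nc3ccccc3N)cc2)cc1` gives 45.7%
- compound 2 `COc1ccc(SCc2ccc(C(=O)Nc3ccccc3N)cc2)cc1OC` gives 19.9%

Compound 1 holds the higher of these two numbers, and the gap lies beyond the scatter. Compound 3 `Nc1ccccc1NC(=O)c1ccc(CSCCc2ccccc2)cc1` keeps the core of compound 1 with one change: phenethyl in place of 4-methoxyphenyl on a sulfur. Going by the values given here, only one measured step bears on this, and only loosely. A methoxy in place of hydrogen on an aromatic carbon gave a number 25.8 percentage points lower from compound 1 to compound 2 (beyond the scatter), a modest step. Among the compounds with values here, it suggests that changes at this end of the molecule can matter, but no measured compound carries phenethyl, so direction stays uncertain. A modest fall in this assay is expected, with a number 9.7 percentage points lower from compound 1 to compound 3 (within the scatter) as the estimated step. For compound 3 the expected value is 36%, within an estimated range of 14% to 58%.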

Compound 3, percent growth inhibition at one concentration: 44.9%
The estimate for compound 3 lay 8.9 percentage points below the measured number; the range from low to high includes it.
By their numbers in this assay, from the lowest: compound 2; then compounds 3 and 1 (each within the scatter of the next).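

In this assay, phenethyl in place of 4-methoxyphenyl on a sulfur gives a number 0.8 percentage points lower from compound 1 to compound 3 (within the scatter), so the two compounds cannot be told apart. Unlike the methoxy step to compound 2, this swap of a whole group leaves the number where it was, showing that the aromatic ring need not sit directly on the sulfur and that the methoxy group of compound 1 is not required. No measurement here explains this match. The compounds shown leave open whether a benzyl group or a longer phenylpropyl chain on the sulfur would give the same result. An amine on the phenethyl ring also remains an open case.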